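The source may hold more compounds than are shown below. What is called first, only, known or untested is meant among the compounds shown, and "the series" means these compounds.

Compound 1: `Cn1c(=O)c(S(=O)(=O)c2ccc(C(=O)O)cc2)cc2cnc(Nc3ccc4[nH]ccc4c3)nc21`, 10000 nM
Compound 2: `Cn1c(=O)c(S(=O)(=O)c2ccc(OC(=O)CCCCC3SCC4NC(=O)NC43)cc2)cc2cnc(Nc3ccc4[nH]ccc4c3)nc21`, 150 nM

Both were tested in a functional assay on DU-145 cells (Homo sapiens) for inhibition, read by trypan blue exclusion, with a stated time of 72 h; a lower number here means a stronger inhibitor, a higher number a weaker inhibitor. Of the two numbers shown, compound 1 has the higher one, and the gap to compound 2 lies well beyond the scatter, so compound 1 is the weaker of the pair. Compound 3, `Cn1c(=O)c(S(=O)(=O)Nc2ccc(F)cc2)cc2cnc(Nc3ccc4[nH]ccc4c3)nc21`, is not yet measured. It differs from compound 1 in one place: (4-fluorophenyl)amino in place of 4-carboxyphenyl on a sulfonyl sulfur. Among the measured compounds shown here, no measured pair shows this change, so there is no measured step to lean on. Compound 2 does show that the shared core can reach a much lower number. I expect the step of a 10-fold lower number from compound 1 to compound 3 (1.00 log units; beyond the scatter) to lower the number beyond the scatter. I estimate compound 3 at 1000 nM, within 200 nM to 5000 nM.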

Compound 3, half-maximal inhibitory concentration: 5000 nM
For compound 3 the middle estimate is 5.0-fold (0.70 log units) below the measured one; measured number inside the range.
By their numbers in this assay, from the lowest: compound 2; then compounds 3 and 1 (each within the scatter of the next).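

In this assay, putting (4-fluorophenyl)amino in place of 4-carboxyphenyl on the sulfonyl sulfur gives a 2.0-fold lower number from compound 1 to compound 3 (0.30 log units; within the scatter), so these two groups cannot be told apart at this position. The swap removes the carboxylic acid and brings in both a nitrogen link and a fluorine, and this single step cannot separate their contributions. No measurement shown here explains the result. Still open, from the compounds shown here alone, is how a plain phenyl group or a 4-methoxyphenyl group on the sulfonyl sulfur would compare, and whether a morpholine there would fit this picture.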